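A few compounds are considered here, and "the series" means these few. Any claim that something is new, unique, unknown or untested is made for them only; others in the source may bear on it.

Working notes on the series. Compound 1 `CC1CCN(C(=O)CN(C)C(=O)c2ccc(S(C)(=O)=O)c([N+](=O)[O-])c2)CC1`, compound 2 `CC1CCN(C(=O)CCNC(=O)c2ccc(S(C)(=O)=O)c([N+](=O)[O-])c2)CC1` and compound 3 `CS(=O)(=O)c1ccc(C(=O)N2CCC(C(=O)N3CCc4ccccc4C3)CC2)cc1[N+](=O)[O-]` share a core and differ only in the amide-linked tail. In an assay on isolated protein for inhibition of vitamin D3 receptor (Homo sapiens), read by fluorescence polarization (a higher number here means a weaker inhibitor, a lower number a stronger inhibitor), compound 1 gives > 60000 nM, a limit rather than a number. Compound 2 in this assay likewise gives only a limit, > 60000 nM. Compound 3 in this assay also sits at a limit, > 60000 nM. Compound 2 thus stands at the limit of > 60000 nM in this assay, at which 3 of the 3 values shown sit, and no measured value sets it apart from the others. Compound 4 `CS(=O)(=O)c1ccc(C(=O)NCCCC(=O)N2CCCCC2)cc1[N+](=O)[O-]` is not yet measured; it differs from compound 2 as ((piperidin-1-yl)carbonyl)methyl in place of (4-methylpiperidin-1-yl)carbonyl on a saturated chain carbon, two bonds along the chain from an amide-type nitrogen. Among the compounds with values here, no step between measured compounds is available, so no direction can be drawn from the series. The expected step that the limit leaves unreadable from compound 2 to compound 4 is none beyond the scatter. The estimate for compound 4 is 80000 nM, from 20000 nM to 300000 nM.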

Compound 4, half-maximal inhibitory concentration: > 60000 nM
Compound 4: a limit, no number; the forecaster's own chance of this, stated with the estimate: 85%; the middle value does not contradict the limit.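

Within the data shown here, compound 2 and compound 4 both give only a limit in this assay, so no step between them can be read. The compounds shown leave open which amide-linked tail, if any, would give a measurable value in this assay.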